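The compounds below may be only part of what the source reports. "The series", "measured", "known", "first", "only" and "open" are said of these compounds alone.

In an assay on HEK293 cells for antagonist activity at transient receptor potential M8 protein (Canis lupus familiaris), read by fluorescence and calcium flux, with a stated time of 5 min (a higher number here means a weaker inhibitor, a lower number a stronger inhibitor), compound 1 `O=C(C(Nc1ccccc1)c1ccc(C(F)(F)F)cc1)N1CCCC1c1ccccc1` gives 60 nM, compound 2 `O=C(C(Nc1ccccc1)c1ccc(C(F)(F)F)cc1)N1CCCC1c1ccccc1F` gives 30 nM, and compound 3 `O=C(C(Nc1ccccc1F)c1ccc(C(F)(F)F)cc1)N1CCCC1c1ccccc1F` gives 7 nM. The two measured steps are a 2.0-fold lower number from compound 1 to compound 2 (0.30 log units; within the scatter) and a 4.3-fold lower number from compound 2 to compound 3 (0.63 log units; beyond the scatter), so compound 3 holds the lowest number of the three. Compound 4 `O=C(O)c1cccc(C2CCCN2C(=O)C(Nc2ccccc2F)c2ccc(C(F)(F)F)cc2)c1` differs from compound 3 by 3-carboxyphenyl in place of 2-fluorophenyl on a saturated ring carbon. Going by these compounds, both measured steps were a fluoro in place of hydrogen on an aromatic carbon; neither exchanges one aryl ring for another, so neither bears directly on this change, and the direction of the step in this assay stays open. Compound 4 is therefore expected to give about 100 nM, within 20 nM to 600 nM, an estimated step of a 14-fold higher number from compound 3 to compound 4 (1.15 log units; beyond the scatter) that leans weakly toward a higher number.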

Compound 4, half-maximal inhibitory concentration: 40 nM
The estimate for compound 4 lay 2.5-fold (0.40 log units) above the measured number; low and high end bracket the measured number.
By their numbers in this assay, from the lowest: compound 3; then compounds 2, 4 and 1 (each within the scatter of the next).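

In this assay, exchanging one aryl ring for another on this saturated ring carbon gives a 5.7-fold higher number from compound 3 to compound 4 (0.76 log units; beyond the scatter), a step the fluoro replacements could not show. The position therefore responds to this change, but compound 4, which carries a carboxylic acid, still gives 40 nM. Nothing available explains the size of the step. The compounds shown leave open how much of the step comes from losing the fluoro group and how much from gaining the carboxylic acid. They also leave open whether a methyl ester or an amine on this ring would give a number nearer that of compound 3.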